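A carboxy group replaces vinyl on the side chain

A few compounds are considered here, and "the series" means these few. Any claim that something is new, unique, unknown or untested is made for them only; others in the source may bear on it.

Among the compounds with values here, in a functional assay (trachea) with Cavia porcellus as the target (on this read-out higher numbers stand for an effect only at larger amounts of compound and lower numbers for an effect already at smaller amounts), compound 1 `CCCn1cnc2c1c(=O)n(C)c(=O)n2CCC` gives 5000 nM, and compound 2 `C=CCCn1cnc2c1c(=O)n(C)c(=O)n2CCC` gives 16800 nM, the higher of the two numbers so far. Compound 3 `CCCn1c(=O)n(C)c(=O)c2c1ncn2CCC(=O)O` has carboxy in place of vinyl on a saturated chain carbon, two bonds along the chain from an aromatic nitrogen. Within the data shown here, only one measured step bears on this place: a 3.4-fold higher number from compound 1 to compound 2 (0.53 log units; beyond the scatter), for vinyl in place of methyl, so a further rise of similar or larger size is expected, though one step is a thin guide. The expected change is a 3.0-fold higher number from compound 2 to compound 3 (0.47 log units; beyond the scatter). The estimate for compound 3 is 50000 nM, with an expected range of 12000 nM to 200000 nM.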

Compound 3, half-maximal effective concentration: > 100000 nM
Compound 3 ended at the assay's limit; the forecaster's own chance of this, stated with the estimate: 30%; middle value at least 2.0-fold (0.30 log units) from the limit.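

Within the data shown here, at this position, the carboxy group is the first change to give a large step: in this assay, carboxy in place of vinyl gives an at least 5.9-fold higher number from compound 2 to compound 3 (0.77 log units; beyond the scatter), and carboxy in place of methyl gives an at least 20-fold higher number from compound 1 to compound 3 (1.30 log units; beyond the scatter). Compound 3 stands at a limit and not at a number, so both steps give only a minimum size: the limit of > 100000 nM in this assay, at which 1 of the 3 values shown sits.

Still open, going by these compounds, is whether this loss of effect belongs to the carboxy group itself, or would also appear with an amine, a methyl ester or a longer chain ending in a carboxylic acid.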